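The source may report more compounds than this note shows. Statements on the series, on what has been measured and on what is new or still open speak of the compounds shown alone.

Compound 1 `Cn1cncc1CN1CC(N(CC2CCN(C(=O)C3CCCC3)CC2)S(=O)(=O)c2ccccn2)Cc2cc(C#N)ccc21` is the reference point of this short set. In an ADME assay on Caco-2 cells (Homo sapiens) for permeability, in the apical to basolateral direction (a higher number here means that the compound crosses the layer faster, a lower number that the compound crosses the layer more slowly), compound 1 gives 0.5 10^-6 cm/s, the highest of the three numbers recorded so far. Compound 2 `CCS(=O)(=O)N1CCC(CN(C2Cc3cc(C#N)ccc3N(Cc3cncn3C)C2)S(=O)(=O)c2ccccn2)CC1` gives 0.1 10^-6 cm/s and compound 3 `Cn1cnc(S(=O)(=O)N2CCC(CN(C3Cc4cc(C#N)ccc4N(Cc4cncn4C)C3)S(=O)(=O)c3ccccn3)CC2)c1` gives 0.1 10^-6 cm/s. Both differ from compound 1 at the same place, an amine nitrogen in a ring: a 5.0-fold lower number from compound 1 to compound 2 (0.70 log units; beyond the scatter), and a 5.0-fold lower number from compound 1 to compound 3 (0.70 log units; beyond the scatter). Between the two sulfonyl compounds, no change at the digits printed from compound 2 to compound 3 (within the scatter).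

Compound 4 `CC(C)C(=O)N1CCC(CN(C2Cc3cc(C#N)ccc3N(Cc3cncn3C)C2)S(=O)(=O)c2ccccn2)CC1` has not yet been measured. It differs from compound 1 in a single place: isopropyl in place of cyclopentyl on a carbonyl carbon. Within the data shown here, the carbonyl on that nitrogen is kept, and only the group on the carbonyl carbon is exchanged, so none of the measured steps repeats this change. The two steps that touch the same nitrogen, from compound 1 to compound 2 and from compound 1 to compound 3, swapped the whole cyclopentylcarbonyl for a sulfonyl group and each cost a modest but real amount, whereas the exchange in compound 4 is a smaller one in what leaves and what enters. Compound 4 is therefore expected to stay close to the reference value, and the expected step is a 1.3-fold lower number from compound 1 to compound 4 (0.10 log units; within the scatter), within the scatter. The estimate for compound 4 is 0.4 10^-6 cm/s, with a range from 0.2 10^-6 cm/s to 0.8 10^-6 cm/s.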

Compound 4, apparent permeability: 0.5 10^-6 cm/s
Compound 4: middle estimate off by 1.3-fold (0.10 log units), on the low side; low and high end bracket the measured number.
By their numbers in this assay, from the lowest: compounds 2 and 3 (each within the scatter of the next); then compounds 1 and 4 (each within the scatter of the next).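

In this assay the group on the carbonyl carbon can go from cyclopentyl to isopropyl, which removes the five-membered ring, with no change at the digits printed from compound 1 to compound 4 (within the scatter) as the result, so among these compounds the read-out at this position does not depend on that ring. With a second carbonyl compound in hand, the gap to the sulfonyl compounds appears again, as a 5.0-fold higher number from compound 3 to compound 4 (0.70 log units; beyond the scatter) and as a 5.0-fold higher number from compound 2 to compound 4 (0.70 log units; beyond the scatter), so it no longer rests on compound 1 alone and holds for both alkyl groups on the carbonyl carbon shown here. Nothing in the information available accounts for either the flat step or the larger ones.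

Among these compounds, only two saturated carbon groups have been seen on this carbonyl carbon, which leaves open how a phenyl ring, a longer chain, an amine or a carboxylic acid at the same place would read. From the compounds shown here alone, it is also open whether isopropyl or cyclopentyl on a sulfonyl sulfur would read like compound 2 and compound 3, which would show whether the sulfonyl itself carries the gap.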